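A few compounds are considered here, and "the series" means these few. Any claim that something is new, unique, unknown or untested is made for them only; others in the source may bear on it.

In an ADME assay on microsomes from liver (Homo sapiens) for metabolic stability, read by LC-MS, with a stated time of 10 min, tested at 0.5 uM (on this read-out lower numbers stand for a less stable compound and higher numbers for a more stable compound), compound 1 (`c1ccc2c(c1)CN[C@@H](CN(CCC1CCNCC1)[C@H]1CCCc3cccnc31)C2`) gives 66%, while compound 2 (`c1ccc2c(c1)CN[C@@H](CN(CCN1CCNCC1)[C@H]1CCCc3cccnc31)C2`) gives 96%, the higher of the two numbers. Compound 3 (`NC(=O)N1CCN(CCCN(C[C@H]2Cc3ccccc3CN2)[C@H]2CCCc3cccnc32)CC1`) differs from compound 2 by (4-carbamoylpiperazin-1-yl)methyl in place of piperazin-1-yl on a saturated chain carbon, two bonds along the chain from an amine nitrogen. Among the compounds with values here, one measured step bears on this change: a number 30 percentage points higher from compound 1 to compound 2 (beyond the scatter), made at the same place on the chain. It does not cover the entering (4-carbamoylpiperazin-1-yl)methyl group. Compound 2 stands at 96%, with little room above it. A modest fall is therefore expected, a number 12 percentage points lower from compound 2 to compound 3 (beyond the scatter). For compound 3 the estimated value is 84%, with an expected range of 62% to 99%.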

Compound 3, percent of the compound remaining: 79%
Beside the measured number, compound 3's estimate is 5 percentage points above it; measured number inside the range.
By their numbers in this assay, from the lowest: compound 1; then compound 3; then compound 2.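

Read in this assay, the larger (4-carbamoylpiperazin-1-yl)methyl group at this place on the chain gives a number 17 percentage points lower from compound 2 to compound 3 (beyond the scatter), so the gain seen with piperazin-1-yl is partly lost. It still retains an advantage over piperidin-4-yl, with a number 13 percentage points higher from compound 1 to compound 3 (beyond the scatter). Nothing measured here gives a reason for either step. The extra methyl carbon and the carbamoyl enter together, so their separate contributions remain unresolved. Open too, as far as these compounds go, is how an unsubstituted piperazin-1-yl on the longer chain, or an acetyl in place of the carbamoyl, would read.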